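Benzoxazole sulfonamides: from hydroxyphenyl to methylphenyl

A few compounds are considered here, and "the series" means these few. Any claim that something is new, unique, unknown or untested is made for them only; others in the source may bear on it.

Compound 2 `O=S(=O)(Nc1ccc(-c2nc3ccccc3o2)cc1)c1ccc(O)cc1` stands only at a limit in an ADME assay on HEK293 cells (Homo sapiens) for cytotoxicity, read by resazurin assay, with a stated time of 48 h; on this read-out higher numbers stand for lower toxicity in this test and lower numbers for higher toxicity in this test: compound 2 gives > 100000 nM, which is a limit of this assay and not a number. Compound 1 `O=S(=O)(Nc1ccc(-c2nc3ccccc3o2)cc1)c1cccc(O)c1` likewise sits at a limit, as compound 1 gives > 100000 nM in this assay. For the measured compounds named here, the one measured step, a step that the two limits leave unreadable from compound 1 to compound 2, is therefore not readable in size, and the only evidence on the series is the limit of > 100000 nM in this assay, at which 2 of the 2 values shown sit.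

Compound 3 `Cc1ccc(S(=O)(=O)Nc2ccc(-c3nc4ccccc4o3)cc2)cc1` differs from compound 2 by methyl in place of hydroxy on an aromatic carbon. Going by the values given here, no measured step bears on this change, since the step between compound 1 and compound 2 leaves its size hidden; both values shown sit at the same limit. Compound 3 is therefore expected to stay at the same limit in this assay, and its expected step is a number no higher from compound 2 to compound 3 (the limit leaves the size open). The estimate for compound 3 is 100000 nM, in the range 40000 nM to 300000 nM.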

Compound 3, half-maximal cytotoxic concentration: 88000 nM
Beside the measured number, compound 3's estimate is 1.1-fold (0.06 log units) above it; measured number inside the range.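

In this assay, for the compounds shown here, compound 3 gives 88000 nM, the first reading that is a number and not a limit. Methyl in place of hydroxy, para to a large group, gives an at least 1.1-fold lower number from compound 2 to compound 3 (0.05 log units; that floor lies within the scatter). The wider change to 4-methylphenyl gives an at least 1.1-fold lower number from compound 1 to compound 3 (0.05 log units; that floor lies within the scatter), so neither printed floor establishes a real shift in toxicity, and the series still rests mainly on one limit: the limit of > 100000 nM in this assay, at which 2 of the 3 values shown sit.

On these data alone, the true size of both steps remains unknown, with the hydroxy end of each step known only as a limit. Also open, as far as these compounds go, is where the number in this test would fall with an amine, a carboxylic acid or a longer chain such as propyl at this position of the six-membered aromatic ring.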